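Swapping the halogens on the benzyl ether of a sialic acid ligand

This account rests on a few compounds, and the source may have more. Where it says the series, first, only, none or still open, it means among the compounds named here.

Measured compounds:
Compound 1 `CC(=O)N[C@H]1[C@H]([C@@H](O)[C@H](O)CNC(=O)c2ccc(Cl)cc2)O[C@@](OCc2c(F)c(F)c(F)c(F)c2F)(C(=O)O)C[C@@H]1O`: 6100 nM
Compound 2 `CC(=O)N[C@H]1[C@H]([C@@H](O)[C@H](O)CNC(=O)c2ccc(Cl)cc2)O[C@@](OCc2cccc(Cl)c2Cl)(C(=O)O)C[C@@H]1O`: 4300 nM

These values come from an in vitro assay on cells for binding affinity to myelin-associated glycoprotein (Mus musculus), read by surface plasmon resonance; on this read-out higher numbers stand for weaker binding and lower numbers for tighter binding. The step of a 1.4-fold lower number from compound 1 to compound 2 (0.15 log units; within the scatter) means compound 2 and compound 1 cannot be told apart on this assay. Compound 3 `CC(=O)N[C@H]1[C@H]([C@@H](O)[C@H](O)CNC(=O)c2ccc(Cl)cc2)O[C@@](OCc2cccc(F)c2F)(C(=O)O)C[C@@H]1O` has not been measured; it differs from compound 2 by 2,3-difluorophenyl in place of 2,3-dichlorophenyl on a saturated chain carbon bound to an oxygen on a saturated carbon. Among the measured compounds shown here, the only step that bears on this change, from a pentafluorophenyl to a dichlorophenyl ring, stayed within the scatter, so compound 3 is expected to sit close to compound 2, with a 1.2-fold higher number from compound 2 to compound 3 (0.07 log units; within the scatter) not beyond the scatter. The estimate for compound 3 is 5000 nM, in the range 2500 nM to 10000 nM.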

Compound 3, dissociation constant: 2400 nM
Beside the measured number, compound 3's estimate is 2.1-fold (0.32 log units) above it; the whole stated range lies above it.
By their numbers in this assay, from the lowest: compounds 3, 2 and 1 (each within the scatter of the next, the first and the last beyond it).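

In this assay, this position now shows a step beyond the scatter: a 2.5-fold lower number from compound 1 to compound 3 (0.41 log units; beyond the scatter), a modest change when the 2,3-difluorophenyl group replaces the 2,3,4,5,6-pentafluorophenyl group. The swap of chlorine for fluorine on the same ring pattern gives a 1.8-fold lower number from compound 2 to compound 3 (0.25 log units; within the scatter), so compound 2 and compound 3 cannot be told apart. No measurement here explains either step.

Still open, as far as these compounds go, is how a plain phenyl ring without halogens, or a ring carrying a methoxy group or an amine, would behave at this position.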